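The compounds below may be only part of what the source reports. "The series", "measured", "known", "first", "only" and "open" are said of these compounds alone.

Measured so far:
Compound 1, `CCOC(=O)c1c(-c2cc(F)cc(OC)c2)[nH]c2cc(OC)ccc2c1=O`, in an ADME assay on Raji cells (Homo sapiens) for cytotoxicity, read by luminescence, with a stated time of 72 h (a higher number here means that more compound is needed for the effect, a lower number that less compound is needed), gives > 21500 nM, which is a limit of the assay.
Compound 2, `CCOC(=O)c1c(-c2cccc(Br)c2)[nH]c2cc(OC)ccc2c1=O`, gives > 21500 nM, again a limit of the assay.
Compound 3, `CCOC(=O)c1c(-c2cccc(Br)c2)[nH]c2cc(OC)c(Cl)cc2c1=O`, gives > 21500 nM, also a limit of the assay.

The core of compound 3 differs from that of compound 2 by chloro in place of hydrogen on an aromatic carbon, and the step is a step that the two limits leave unreadable from compound 2 to compound 3. Compound 1 arises from compound 2 by 3-fluoro-5-methoxyphenyl in place of 3-bromophenyl on an aromatic carbon, and the step is a step that the two limits leave unreadable from compound 2 to compound 1. Both steps are unreadable because of the limit of > 21500 nM in this assay, at which 3 of the 3 values shown sit.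

Compound 4, `CCOC(=O)c1c(-c2cc(F)cc(OC)c2)[nH]c2cc(OC)c(Cl)cc2c1=O`, is not yet measured in this assay. It arises from compound 3 by 3-fluoro-5-methoxyphenyl in place of 3-bromophenyl on an aromatic carbon, the same change as that from compound 2 to compound 1, made around the same place. For compound 4 the expected step is a step that the limit leaves unreadable from compound 3 to compound 4, resting on compound 1, compound 2 and compound 3 all sitting at the limit of > 21500 nM in this assay, at which 3 of the 3 values shown sit. Compound 4 is therefore estimated at 30000 nM, most likely reported only as a limit, with the expected range from 12000 nM to 100000 nM.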

Compound 4, half-maximal effective concentration: > 21500 nM
Compound 4 ended at the assay's limit; the forecaster's own chance of this, stated with the estimate: 85%; the middle value does not contradict the limit.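

Neither the step from compound 3 to compound 4 nor the step from compound 1 to compound 4 can be read in this assay, because all of these compounds sit at one limit: the limit of > 21500 nM in this assay, at which 4 of the 4 values shown sit.

The compounds shown leave open how much of any of them is needed for the effect, and so whether either change alters that amount at all.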